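The compounds below may be only part of what the source reports. "The series", "measured", "known", "first", "only" and "open" are said of these compounds alone.

Measured so far in a functional assay on the whole organism (Tail, strain ICR) with Mus musculus as the target, in the tail flick test, with a stated time of 90 min, at a dose of 25 umol/kg by the oral route; on this read-out lower numbers stand for a weaker effect and higher numbers for a stronger effect at the one dose given:
compound 1, `C[C@@H](O)[C@H](NC(=O)CN(c1nc(Cl)nc2[nH]cnc12)C1CC1)C(=O)OCc1ccccc1`: 29.9%
compound 2, `C[C@@H](O)[C@H](NC(=O)CN(c1nc(Cl)nc2[nH]cnc12)C1CC1)C(=O)O`: 35.9%
compound 3, `CC(C)C[C@H](NC(=O)CN(c1nc(Cl)nc2[nH]cnc12)C1CC1)C(=O)OCc1ccccc1`: 15.2%

Compound 1 and compound 2 differ by hydrogen in place of benzyl on an oxygen next to a carbonyl group, and this step gives a number 6 percentage points higher from compound 1 to compound 2 (within the scatter), so the two values cannot be told apart. Compound 1 and compound 3 differ in their core by isobutyl in place of 1-hydroxyethyl on a saturated chain carbon bound to an amide-type nitrogen and a carbonyl carbon, and this step gives a number 14.7 percentage points lower from compound 1 to compound 3 (beyond the scatter), leaving compound 3 with the lowest of the three numbers in this assay, beyond the scatter from both of the others.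

Compound 4, `CC(C)C[C@H](NC(=O)CN(c1nc(Cl)nc2[nH]cnc12)C1CC1)C(=O)O`, is not yet measured in this assay. It differs from compound 3 by hydrogen in place of benzyl on an oxygen next to a carbonyl group, which is the same change as that from compound 1 to compound 2: the place is the same, on an oxygen next to a carbonyl group whose other neighbour is the carbonyl carbon. The only basis for an expectation is the earlier step, which is expected to repeat on the core of compound 3 as a number 5.8 percentage points higher from compound 3 to compound 4 (within the scatter), a small step because a number 6 percentage points higher from compound 1 to compound 2 (within the scatter) lay within the scatter. Compound 4 is therefore estimated at 21% in this assay, expected to fall between 9% and 35%. For the measured compounds named here, whether the removal of benzyl behaves alike on both cores is not known from the compounds so far.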

Compound 4, a percentage reported as activity, at one dose (the size of the read-out at that dose, not a potency): 27%
Compound 4: the middle estimate sits 6 percentage points below what was measured; the range from low to high includes it.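

In this assay, hydrogen in place of benzyl on an oxygen next to a carbonyl group gives a number 11.8 percentage points higher from compound 3 to compound 4 (beyond the scatter), and the two readings of this change agree: the same change on two cores in this assay, a number 6 percentage points higher (within the scatter) from compound 1 to compound 2 and a number 11.8 percentage points higher (beyond the scatter) from compound 3 to compound 4, 5.8 percentage points apart, within the scatter of two such steps. Isobutyl in place of 1-hydroxyethyl gives a number 8.9 percentage points lower from compound 2 to compound 4 (within the scatter), and this change also reads alike on both cores: the same change on two cores in this assay, a number 14.7 percentage points lower (beyond the scatter) from compound 1 to compound 3 and a number 8.9 percentage points lower (within the scatter) from compound 2 to compound 4, 5.8 percentage points apart, within the scatter of two such steps. Across these four compounds, each change carries from one core to the other without a gap beyond the scatter, but this rests on only two cores and one dose and time, and it does not fix the size of either step on any further core.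

On these data alone, it remains open whether the same agreement holds for a methyl ester or a primary amide in place of the carboxy group. Also open, as far as these compounds go, is how a longer chain or an amine in place of isobutyl would read in this assay.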